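This account rests on a few compounds, and the source may have more. Where it says the series, first, only, none or still open, it means among the compounds named here.

Measured in a functional assay on KB-V1 cells (Homo sapiens) for cytotoxicity, read by MTT assay, with a stated time of 72 h; a lower number here means a stronger inhibitor, a higher number a weaker inhibitor:
- Compound 1 `O=C1Nc2ccccc2/C1=N/NC(=S)Nc1cccnc1`: > 50000 nM, a limit of the assay
- Compound 2 `O=C1Nc2ccccc2/C1=N/NC(=S)Nc1cccc(Cl)c1`: 640 nM

Among the compounds with values here, compound 2 is the only compound with an actual number so far. Within the data shown here, the one measured step, an at least 78-fold lower number from compound 1 to compound 2 (1.89 log units; beyond the scatter), is large, but it starts from a limit of > 50000 nM in this assay, at which 1 of the 2 values shown sits, and replaces pyridin-3-yl, so it gives no size for a swap between chlorophenyl groups. Next is compound 3 `O=C1Nc2ccccc2/C1=N/NC(=S)Nc1ccc(Cl)cc1`, with 4-chlorophenyl in place of 3-chlorophenyl on an amide-type nitrogen. In this assay, no step beyond the scatter is expected, and no direction is favoured. The expected change is a 1.1-fold lower number from compound 2 to compound 3 (0.03 log units; within the scatter). Compound 3 is estimated at 600 nM, with an expected range of 200 nM to 2000 nM.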

Compound 3, half-maximal inhibitory concentration: 4990 nM
Compound 3: middle estimate off by 8.3-fold (0.92 log units), on the low side; measured number outside the range, above it.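

In this assay, 4-chlorophenyl in place of 3-chlorophenyl on the amide-type nitrogen gives a 7.8-fold higher number from compound 2 to compound 3 (0.89 log units; beyond the scatter), so this place separates two groups made of the same atoms. As far as these compounds go, both chlorophenyl groups still stand apart from pyridin-3-yl, with 4-chlorophenyl giving an at least 10-fold lower number from compound 1 to compound 3 (1.00 log units; beyond the scatter) as a step whose full size stays unknown, since it starts from a limit: the limit of > 50000 nM in this assay, at which 1 of the 3 values shown sits.

Open, from the compounds shown here alone, is how methoxy or trifluoromethyl in place of the chlorine would behave. Also open, going by these compounds, is what an unsubstituted phenyl gives on this nitrogen.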